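The source may hold more compounds than are shown below. What is called first, only, known or untested is meant among the compounds shown, and "the series" means these compounds.

Measured compounds:
compound 1 `COc1ccc(C2=NN(C3=NC(=O)/C(=C4\C(=O)Nc5ccc(Br)cc54)S3)C(c3ccc(OC)cc3)C2)cc1`: 410 nM in a functional assay on cells (Melanoma cell, Homo sapiens) for cytotoxicity, read by sulforhodamine B assay, with a stated time of 48 h; a lower number here means a stronger inhibitor of growth, a higher number a weaker inhibitor of growth
compound 2 `COc1ccc(C2=NN(C3=NC(=O)/C(=C4\C(=O)Nc5ccc(Cl)cc54)S3)C(c3ccc(OC)cc3)C2)cc1`: 380 nM in this assay

Compound 1 gives the higher of the two numbers in this assay, but its nearest neighbour, compound 2, lies only a 1.1-fold lower number from compound 1 to compound 2 (0.03 log units; within the scatter) away, so the two compounds cannot be told apart on these data. That single step is the only measured one, and it changes a halogen on an aromatic carbon: a chloro in place of a bromo on the shared core, which left the number essentially unchanged.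

Compound 3 `COc1ccc(C2CC(c3ccc4ccccc4c3)=NN2C2=NC(=O)/C(=C3\C(=O)Nc4ccc(Br)cc43)S2)cc1` differs from compound 1 in another part of the molecule: naphthalen-2-yl in place of 4-methoxyphenyl on a carbon with a double bond to nitrogen. For the measured compounds named here, no measured step concerns this position, so nothing in the data points in either direction for this change. Going by the values given here, the one known step, from compound 1 to compound 2, bears on it only indirectly, by showing that a small change elsewhere on the core moved the number by an amount within the scatter.

Among the compounds with values here, with no step to lean on, compound 3 is estimated to give 420 nM in this assay, with a range from 140 nM to 1300 nM. From the compounds shown here alone, the expected step from compound 1 to compound 3 is a 1.0-fold higher number from compound 1 to compound 3 (0.01 log units; within the scatter), which is no change beyond the scatter, though the wide range reflects that the change is untested.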

Compound 3, concentration for total growth inhibition: 190 nM
For compound 3 the middle estimate is 2.2-fold (0.34 log units) above the measured one; measured number inside the range.
By their numbers in this assay, from the lowest: compounds 3, 2 and 1 (each within the scatter of the next, the first and the last beyond it).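

For the compounds shown here, the place on the carbon with a double bond to nitrogen, which no earlier step had touched, turns out to matter in this assay: naphthalen-2-yl in place of 4-methoxyphenyl gives a 2.2-fold lower number from compound 1 to compound 3 (0.33 log units; beyond the scatter). This is a modest step, but unlike the swap of halogens on the shared core, it lies beyond the usual scatter, so this position accepts the bigger group with two six-membered aromatic rings and the number still moves in the favourable direction. No measurement available here says what lies behind this step.

The swap alters two things at once, removing the methoxy oxygen and adding a second aromatic ring, so these compounds cannot show which of the two counts, and a plain phenyl group at this position would be the natural way to begin separating them. Also open, from the compounds shown here alone, are whether a naphthalen-2-yl group gives a similar step on the chloro core of compound 2, and how a group of a different kind, such as an amine or a carboxylic acid on the aromatic ring, would fare here.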